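Carboxyphenyl swap on the shared core of compound 1

This account rests on a few compounds, and the source may have more. Where it says the series, first, only, none or still open, it means among the compounds named here.

Measured so far in an ADME assay on microsomes from liver (Rattus norvegicus) for metabolic stability, read by LC-MS, with a stated time of 1 h, at 37 degrees C, tested at 4 uM; on this read-out higher numbers stand for a more stable compound and lower numbers for a less stable compound:
compound 1 `O=C(O)c1ccc(-c2cccc(COc3ccc4c(c3)CN(C3CCCC3)C4=O)c2)c(Cl)c1`: 3%
compound 2 `Cn1sc2cc(OCc3cccc(-c4ccc(Cl)c(C(=O)O)c4)c3)ccc2c1=O`: 84%
compound 3 `CC(C)Cn1sc2cc(OCc3cccc(-c4ccc(Cl)c(C(=O)O)c4)c3)ccc2c1=O`: 86%

Compound 1 stands lowest of the three numbers in this assay; compound 2 and compound 3 both lie far above it, beyond the scatter, and differ from each other only by a number 2 percentage points higher from compound 2 to compound 3 (within the scatter), which is within the scatter. That one step concerns an isopropyl in place of hydrogen on a saturated chain carbon bound to an aromatic nitrogen, on a core unlike that of compound 1, and says nothing about the carboxyphenyl end of the molecule.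

Compound 4 `Cc1ccc(C(=O)O)cc1-c1cccc(COc2ccc3c(c2)CN(C2CCCC2)C3=O)c1` keeps the core of compound 1 and changes only the aryl group: 5-carboxy-2-methylphenyl in place of 4-carboxy-2-chlorophenyl on an aromatic carbon. Going by the values given here, no measured pair shows this change or anything at this place, so there is no step to lean on; the only anchor is compound 1 itself, with 3%. On that basis the expectation is a number close to compound 1, with a step of a number 5 percentage points higher from compound 1 to compound 4 (within the scatter) that may well stay within the scatter. Compound 4 is therefore estimated at 8%, in a range from 0% to 35% in this assay.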

Compound 4, percent of the compound remaining: 2%
Beside the measured number, compound 4's estimate is 6 percentage points above it, within the range that was stated.
By their numbers in this assay, from the lowest: compounds 4 and 1 (each within the scatter of the next); then compounds 2 and 3 (each within the scatter of the next).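

In this assay, going by these compounds alone, this is the first reading at this place on the shared core, and 5-carboxy-2-methylphenyl in place of 4-carboxy-2-chlorophenyl gives a number 1 percentage points lower from compound 1 to compound 4 (within the scatter). On the core of compound 1, the read-out therefore does not separate these two aryl groups, even though the swap exchanges chlorine for methyl and 4-carboxy for 5-carboxy at once, and this single pair cannot show what either exchange does alone. Nothing available bears on why the number stays where it does.

Still open, as far as these compounds go, is whether a tetrazole in place of the carboxylic acid, or a fluorine or methoxy in place of the chlorine or methyl, would give a different number in this assay on this core. Also open, from the compounds shown here alone, is whether any aryl group at this place can shift the read-out on the core of compound 1, or whether a change elsewhere on that core, such as an amine on its saturated ring, would be needed.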